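Oxime-ether series on prostate carcinoma cells: compound 4 outlook

A few compounds are considered here, and "the series" means these few. Any claim that something is new, unique, unknown or untested is made for them only; others in the source may bear on it.

Measured so far:
- compound 1 `COc1cc2c(cc1CC=C(C)C)C(=O)C[C@@H](c1ccc(Oc3cccc([N+](=O)[O-])c3)cc1)O2`: 21%
- compound 2 `COc1ccc([C@@H]2C/C(=N/OCc3cn(-c4cccc(CO)c4)nn3)c3cc(CC=C(C)C)c(OC)cc3O2)cc1`: 34%
- compound 3 `COc1cc2c(cc1CC1OC1(C)C)C(=O)C[C@@H](c1ccc(O)cc1)O2`: 92%

All three were run in a functional assay on PC-3 cells (Homo sapiens) for inhibition, read by sulforhodamine B assay, with a stated time of 48 h, tested at 50 uM; on this read-out lower numbers stand for less inhibition of growth and higher numbers for more inhibition of growth at the one concentration tested. Compound 3 gives 92% and stands furthest from the rest. Compound 2 holds the second highest of the three numbers: its nearest neighbour is compound 1, lower by a gap beyond the usual scatter, and compound 3 lies far higher, again beyond the scatter. Among the measured compounds shown here, compounds 1 and 3 share a ketone core, whereas compound 2 carries the oxime ether with a triazole and an aryl group on the ring nitrogen, so no single-point step between measured compounds is available.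

Compound 4 `COc1ccc([C@@H]2C/C(=N/OCc3cn(-c4ccc(C(N)=O)cc4)nn3)c3cc(CC=C(C)C)c(OC)cc3O2)cc1` is the next member. It differs from compound 2 in one place: 4-carbamoylphenyl in place of 3-(hydroxymethyl)phenyl on an aromatic nitrogen. The leaving and entering groups each carry one hydrogen-bond donor and one hydrogen-bond acceptor and sit on the same aromatic nitrogen, so the change is modest in size and position.

For the measured compounds named here, with no measured step of this kind to lean on, the expectation for the step from compound 2 to compound 4 is a number 1 percentage points higher from compound 2 to compound 4 (within the scatter), that is, nothing beyond the scatter in either direction. Compound 4 is therefore estimated at 35%, with a range from 15% to 60%.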

Compound 4, percent growth inhibition at one concentration: 100%
Beside the measured number, compound 4's estimate is 65 percentage points below it; measured number above the stated range.
By their numbers in this assay, from the lowest: compound 1; then compound 2; then compounds 3 and 4 (each within the scatter of the next).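

In this assay, the aryl group on the aromatic nitrogen of the five-membered ring proves to be a sensitive place in the oxime-ether series: 4-carbamoylphenyl in place of 3-(hydroxymethyl)phenyl gives a number 66 percentage points higher from compound 2 to compound 4 (beyond the scatter). The leaving and entering groups have the same counts of hydrogen-bond donors and acceptors, carry no net charge and differ by a single heavy atom, so these counts do not track the size of the step. No measurement shown here accounts for the step.

The step changes the functional group and its numbered place on the phenyl ring together, so the compounds shown cannot separate the two; 3-carbamoylphenyl and 4-(hydroxymethyl)phenyl would form the missing links between compound 2 and compound 4. They also leave open whether the primary amide itself matters at this place, a question that a carboxylic acid, a nitrile or an N,N-dimethylcarbamoyl group at the same ring position could address.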